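Methoxy on the benzylamide ring of the shared core

The source may hold more compounds than are shown below. What is called first, only, known or untested is meant among the compounds shown, and "the series" means these compounds.

The shared core is that of compound 1 `CC(C)Cc1ccc(C(C)C(=O)NCc2ccccc2)cc1`. Going by the values given here, in an assay on brain for inhibition of Fatty-acid amide hydrolase 1 (Rattus norvegicus), read by scintillation counting, with a stated time of 10 min (a lower number here means a stronger inhibitor, a higher number a weaker inhibitor), compound 1 gives 21000 nM, the lowest of the three numbers measured so far; compound 3 `CC(C)Cc1ccc(C(C)C(=O)NCc2cccc(C(F)(F)F)c2)cc1` gives 28000 nM and compound 2 `CC(C)Cc1ccc(C(C)C(=O)NCc2ccc(C(F)(F)F)cc2)cc1` gives 51000 nM. Of the two steps from compound 1, the step of a 2.4-fold higher number from compound 1 to compound 2 (0.39 log units; beyond the scatter) lies beyond the scatter, while the step of a 1.3-fold higher number from compound 1 to compound 3 (0.12 log units; within the scatter) does not. Both carry trifluoromethyl in place of hydrogen on an aromatic carbon.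

Compound 4 `COc1ccccc1CNC(=O)C(C)c1ccc(CC(C)C)cc1` differs from compound 1 by methoxy in place of hydrogen on an aromatic carbon. Among the compounds with values here, no measured step introduces methoxy, and none places a group on the aromatic carbon that is ortho to a large group, so the two trifluoromethyl steps bear on this change only as a rough guide to how much this ring tolerates a single substituent: one of them left the number essentially unchanged, the other raised it modestly. A small step in this assay is therefore expected, towards a higher number if anything, most likely within the scatter. The estimate for compound 4 in this assay is 26000 nM with a range of 11000 nM to 60000 nM, which is expected to correspond to a step of a 1.2-fold higher number from compound 1 to compound 4 (0.09 log units; within the scatter).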

Compound 4, half-maximal inhibitory concentration: 18000 nM
Beside the measured number, compound 4's estimate is 1.4-fold (0.16 log units) above it, within the range that was stated.
By their numbers in this assay, from the lowest: compounds 4, 1, 3 and 2 (each within the scatter of the next, the first and the last beyond it).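

In this assay, going by these compounds alone, the step of a 1.2-fold lower number from compound 1 to compound 4 (0.07 log units; within the scatter) lies within the scatter, and it is the first reading for a group on an aromatic carbon ortho to a large group. Methoxy at this position therefore leaves the number indistinguishable from that of the unsubstituted compound, much as the trifluoromethyl step a 1.3-fold higher number from compound 1 to compound 3 (0.12 log units; within the scatter) does, whereas the trifluoromethyl step a 2.4-fold higher number from compound 1 to compound 2 (0.39 log units; beyond the scatter) lies beyond the scatter. Across the three substituted compounds, no step from compound 1 gives a lower number beyond the scatter, and no measured evidence bears on why this methoxy step is so small.

From the compounds shown here alone, whether this aromatic carbon accepts other groups equally, such as a hydroxy, an amine or a carboxylic acid, remains open, as does whether a longer chain such as ethoxy would move the number beyond the scatter in either direction. Methoxy on the other aromatic carbons of this ring also remains open, so the effect of its position cannot yet be separated from that of the group itself.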